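This account rests on a few compounds, and the source may have more. Where it says the series, first, only, none or still open, it means among the compounds named here.

In a functional assay on HeLa cells (Homo sapiens) for cytotoxicity, in the presence of a further agent that is not named here (on this read-out lower numbers stand for stronger inhibition and higher numbers for weaker inhibition), compound 1 `Clc1ccc(-c2cc(-c3ccsc3)nc(-c3ccco3)c2)o1` gives > 50000 nM, which is a limit of the assay and not a number.
Compound 2 `Clc1ccc(-c2cc(-c3ccco3)nc(-c3cccs3)c2)o1` gives 18800 nM in this assay.
Compound 3 `Clc1ccc(-c2cc(-c3ccoc3)cc(-c3cccs3)n2)cc1` gives 5530 nM in this assay.

Compound 1 thus sits at the limit of > 50000 nM in this assay, at which 1 of the 3 values shown sits, so only a range is known for it. Compound 4 `Clc1ccc(-c2cc(-c3ccsc3)nc(-c3ccccn3)c2)o1` differs from compound 1 by pyridin-2-yl in place of furan-2-yl on an aromatic carbon. Among the measured compounds shown here, the single measured step, an at least 2.6-fold lower number from compound 1 to compound 2 (0.42 log units; beyond the scatter), concerns a different group; no measured step bears on the exchange of furan-2-yl for pyridin-2-yl. With compound 1 known only as a limit, compound 4 is expected to give about 40000 nM, within 10000 nM to 100000 nM. The expected step of an at least 1.2-fold lower number from compound 1 to compound 4 (0.09 log units; that floor lies within the scatter) is at most modest, and a reported limit again is likely.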

Compound 4, half-maximal inhibitory concentration: 22500 nM
For compound 4 the middle estimate is 1.8-fold (0.25 log units) above the measured one; the range from low to high includes it.
By their numbers in this assay, from the lowest: compound 3; then compounds 2 and 4 (each within the scatter of the next). At a limit, above all of these: compound 1.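

Pyridin-2-yl in place of furan-2-yl, next to the ring nitrogen, gives an at least 2.2-fold lower number from compound 1 to compound 4 (0.34 log units; beyond the scatter) in this assay. Among the compounds shown here, this is the first measured step at this position, and it shows that the number responds to the exchange of one aromatic ring for another there. The size of the step is only a floor, because compound 1 stands at a limit: the limit of > 50000 nM in this assay, at which 1 of the 4 values shown sits.

The compounds shown leave open how a non-aromatic group, such as an amine or a carboxylic acid, would read out at this position.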